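The compounds below may be only part of what the source reports. "The series", "measured", "known", "first", "only" and "open" are said of these compounds alone.

In an ADME assay on L02 cells (Homo sapiens) for cytotoxicity, read by MTT assay, with a stated time of 24 h (on this read-out higher numbers stand for weaker inhibition and lower numbers for stronger inhibition), compound 2 `O=C1/C(=C/c2cccnc2)CNC/C1=C\c1ccccc1F` gives 15900 nM. This stands level with compound 1 `CN1C/C(=C\c2ccncc2)C(=O)/C(=C/c2ccccc2F)C1`, which carries pyridin-4-yl, at 14900 nM and with compound 3 `O=C1/C(=C/c2cccnc2)CN(S(=O)(=O)c2ccc(Br)cc2)C/C1=C\c1ccccc1F` at 14600 nM, as all three values lie within the usual scatter. Compound 4 `O=C1/C(=C/c2ccncc2)CNC/C1=C\c1ccccc1F` has not yet been measured and differs from compound 2 in one group: pyridin-4-yl in place of pyridin-3-yl on a double-bonded chain carbon bound to a double-bonded ring carbon. Within the data shown here, the only measured step, a 1.1-fold lower number from compound 2 to compound 3 (0.04 log units; within the scatter), lies at another place on the molecule, and no measured step makes this exact swap. With so little evidence and such a flat set of values, no step beyond the scatter is expected in this assay. The expected change is a 1.1-fold lower number from compound 2 to compound 4 (0.03 log units; within the scatter). For compound 4 the estimate is 15000 nM, with an expected range of 9000 nM to 25000 nM.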

Compound 4, half-maximal inhibitory concentration: 14700 nM
The estimate for compound 4 lay 1.0-fold (0.01 log units) above the measured number; measured number inside the range.
By their numbers in this assay, from the lowest: compounds 3, 4, 1 and 2 (each within the scatter of the next).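

In this assay, the swap of pyridin-3-yl for pyridin-4-yl on a double-bonded chain carbon bound to a double-bonded ring carbon now has a direct reading: a 1.1-fold lower number from compound 2 to compound 4 (0.03 log units; within the scatter) shows that the assay does not separate the two groups at this place. With pyridin-4-yl held fixed, hydrogen in place of methyl on the ring amine nitrogen gives a 1.0-fold lower number from compound 1 to compound 4 (0.01 log units; within the scatter) and likewise leaves the values level. No measured evidence explains these results. On these data alone, whether a pyridin-2-yl or a plain phenyl group at this place would also stay level remains open.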